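Sulfonyl substituent and human liver microsome stability

The compounds below may be only part of what the source reports. "The series", "measured", "known", "first", "only" and "open" are said of these compounds alone.

Three compounds on one shared core have been run in an ADME assay on microsomes from liver (Homo sapiens) for metabolic stability, with a stated time of 10 min; a lower number here means that less of the compound is left, a higher number that more of the compound is left. Compound 1 `CC(C)NCCS(=O)(=O)NC(=O)c1ccc(Nc2nc(NC3(c4ccc(Cl)cc4)CC3)nc(OCC(F)(F)F)n2)cc1` gives 89%. Compound 2 `CC(C)(C)NC(=O)NCCS(=O)(=O)NC(=O)c1ccc(Nc2nc(NC3(c4ccc(Cl)cc4)CC3)nc(OCC(F)(F)F)n2)cc1` gives 96%. Compound 3 `O=C(NS(=O)(=O)C1CC1)c1ccc(Nc2nc(NC3(c4ccc(Cl)cc4)CC3)nc(OCC(F)(F)F)n2)cc1` gives 100%, the highest of the three numbers: compound 2 sits within the scatter of it, compound 1 lies beyond it. The single-point steps are a number 7 percentage points higher from compound 1 to compound 2 (within the scatter), a number 11 percentage points higher from compound 1 to compound 3 (beyond the scatter) and a number 4 percentage points higher from compound 2 to compound 3 (within the scatter).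

Compound 4 `O=C(NS(=O)(=O)CCNCc1ccccc1)c1ccc(Nc2nc(NC3(c4ccc(Cl)cc4)CC3)nc(OCC(F)(F)F)n2)cc1` is the next member and has not yet been measured in this assay. It differs from compound 3 at one place: 2-(benzylamino)ethyl in place of cyclopropyl on a sulfonyl sulfur. This runs opposite to the two measured steps into compound 3, each of which replaced a two-carbon chain bearing a nitrogen on the sulfonyl sulfur with cyclopropyl; the step from compound 1 to compound 3 was beyond the scatter, the step from compound 2 to compound 3 within it. A fall from compound 3 of similar, modest size is therefore expected for compound 4, and given that compound 3 stands at the top of the measured range the room upward is small. Compound 4 is expected at 87%, with a range from 72% to 99%. This estimate means an expected step of a number 13 percentage points lower from compound 3 to compound 4 (beyond the scatter).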

Compound 4, percent of the compound remaining: 99%
Estimate against measurement, compound 4: 12 percentage points below, and the stated range covers the measured number.
By their numbers in this assay, from the lowest: compounds 1, 2, 4 and 3 (each within the scatter of the next, the first and the last beyond it).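

Replacing cyclopropyl with 2-(benzylamino)ethyl on the sulfonyl sulfur leaves the number in this assay within the scatter (a number 1 percentage points lower from compound 3 to compound 4 (within the scatter)), so this position accepts a much larger group that adds an aromatic ring and an amine nitrogen without a step beyond the scatter. At the amine nitrogen of the chain, benzyl also gives steps within the scatter, both against (tert-butyl)carbamoyl (a number 3 percentage points higher from compound 2 to compound 4 (within the scatter)) and against isopropyl (a number 10 percentage points higher from compound 1 to compound 4 (within the scatter)). Within the data shown here, compound 1 remains the only compound with a printed step beyond the scatter from compound 3, so a nitrogen-bearing chain on the sulfonyl sulfur does not in itself separate a compound from the cyclopropyl analogue, as compound 2 and compound 4 show; nothing available here bears on why these numbers fall as they do.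

With all four compounds close together at the upper end of the read-out, the position's tolerance is only loosely defined. Open questions are whether a carboxylic acid at the end of the chain, a longer chain, or a tertiary amine in place of the secondary amine would give a step beyond the scatter from compound 3.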